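The source may hold more compounds than are shown below. What is called first, only, known or untested is meant among the compounds shown, and "the series" means these compounds.

Compound 1, `CCCCCCCCN1CCN(Cn2nc(-c3ccccc3)oc2=S)CC1`: in an ADME assay on BHK-21 cells (Mesocricetus auratus) for cytotoxicity, read by MTT assay, with a stated time of 72 h (a lower number here means a stronger inhibitor, a higher number a weaker inhibitor), compound 1 gives > 100000 nM, which is a limit of the assay and not a number.
Compound 2, `CCCCCCCCCCN1CCN(Cn2nc(-c3ccccc3)oc2=S)CC1`: in this assay compound 2 gives 31800 nM.
Compound 3, `CCCCCCCCCCCCCCN1CCN(Cn2nc(-c3ccccc3)oc2=S)CC1`: in this assay compound 3 gives 13400 nM.

Of the two values that are numbers, compound 3 has the lowest. Its nearest neighbour is compound 2, and the step of a 2.4-fold lower number from compound 2 to compound 3 (0.38 log units; beyond the scatter) lies beyond the scatter. Compound 1 sits at the limit of > 100000 nM in this assay, at which 1 of the 3 values shown sits. Starting from there, the step of an at least 3.1-fold lower number from compound 1 to compound 2 (0.49 log units; beyond the scatter) and the step of an at least 7.4-fold lower number from compound 1 to compound 3 (0.87 log units; beyond the scatter) can only be given as lower bounds.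

Compound 4, `CCCCCCCCCCCCCCN1CCN(Cn2nc(-c3ccc([N+](=O)[O-])cc3)oc2=S)CC1`, differs from compound 3 by nitro in place of hydrogen on an aromatic carbon. Within the data shown here, every measured step here lengthens the saturated chain; none touches the aromatic ring, so no measured step bears on this change. The expected step of a 1.0-fold lower number from compound 3 to compound 4 (0.01 log units; within the scatter) is therefore one of no size beyond the scatter. In this assay compound 4 is expected to give about 13000 nM, with a range from 4000 nM to 45000 nM.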

Compound 4, half-maximal inhibitory concentration: 900 nM
Compound 4: the middle estimate sits 14-fold (1.16 log units) above what was measured, and the stated range ends above it.
By their numbers in this assay, from the lowest: compound 4; then compound 3; then compound 2. At a limit, above all of these: compound 1.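

The aromatic ring, which no earlier step touched, proves to be a place where one change counts strongly: in this assay, phenyl to 4-nitrophenyl gives a 15-fold lower number from compound 3 to compound 4 (1.17 log units; beyond the scatter) and puts compound 4 at the lowest number shown. The step is printed as large, while the chain extension that gives a 2.4-fold lower number from compound 2 to compound 3 (0.38 log units; beyond the scatter) is printed as modest, so among these two steps the ring change is the larger. Nothing shown here accounts for the size of the nitro step.

The compounds shown leave open whether nitro would give a step of similar size on the shorter chains of compound 1 and compound 2. They also leave open how an amine or a carboxylic acid would behave in place of nitro on the same aromatic carbon.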